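Swapping Fluoro for Methoxy on the Pendant Ring

The source may hold more compounds than are shown below. What is called first, only, known or untested is meant among the compounds shown, and "the series" means these compounds.

Compound 1 `CCn1cc(-c2ccc(F)cc2)c(=O)c2cc(F)c(N3CCNCC3)cc21`: 69600 nM
Compound 2 `CCn1cc(-c2ccc(OC)cc2)c(=O)c2cc(F)c(N3CCNCC3)cc21`: 46100 nM
Compound 3 `CCn1cc(-c2cccc(F)c2)c(=O)c2cc(F)c(N3CCNCC3)cc21`: 27300 nM

These three compounds share one core and differ only in the substituent on the pendant phenyl ring. In a functional assay on BGC-823 cells (Homo sapiens) for antiproliferative activity, read by MTT assay, with a stated time of 48 h (a higher number here means a weaker inhibitor, a lower number a stronger inhibitor), compound 3 has the lowest number of the three: a 1.7-fold lower number from compound 2 to compound 3 (0.23 log units; within the scatter), and a 2.5-fold lower number from compound 1 to compound 3 (0.41 log units; beyond the scatter).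

Compound 4 `CCn1cc(-c2cccc(OC)c2)c(=O)c2cc(F)c(N3CCNCC3)cc21` has not yet been measured. It differs from compound 3 by methoxy in place of fluoro on an aromatic carbon. Among the compounds with values here, the only measured step of the same kind is a 1.5-fold lower number from compound 1 to compound 2 (0.18 log units; within the scatter), which stayed within the scatter. The step of a 1.2-fold lower number from compound 3 to compound 4 (0.09 log units; within the scatter) is therefore expected to be small, with no clear direction beyond the scatter. Compound 4 is estimated at 22000 nM, with a likely range from 9000 nM to 55000 nM.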

Compound 4, half-maximal inhibitory concentration: 14700 nM
Compound 4: the middle estimate sits 1.5-fold (0.18 log units) above what was measured, within the range that was stated.
By their numbers in this assay, from the lowest: compounds 4, 3, 2 and 1 (each within the scatter of the next, the first and the last beyond it).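

The same swap of fluoro for methoxy now appears on a second core, and the two results agree in this assay: the same change on two cores in this assay, a 1.5-fold lower number (0.18 log units; within the scatter) from compound 1 to compound 2 and a 1.9-fold lower number (0.27 log units; within the scatter) from compound 3 to compound 4, 1.2-fold (0.09 log units) apart, within the scatter of two such steps At this position, meta to a large group, the swap gives a 1.9-fold lower number from compound 3 to compound 4 (0.27 log units; within the scatter), so the data do not separate fluoro from methoxy here. The steps beyond the scatter involve the place of the group on the ring: 3-methoxyphenyl in place of 4-methoxyphenyl gives a 3.1-fold lower number from compound 2 to compound 4 (0.50 log units; beyond the scatter), and 3-methoxyphenyl in place of 4-fluorophenyl gives a 4.7-fold lower number from compound 1 to compound 4 (0.68 log units; beyond the scatter).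

Going by these compounds, how an amine, a carboxylic acid or a longer chain such as ethoxy would behave at this position remains open.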